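Notes on compound 4: ester-bearing vinyl in place of amide

The compounds below may be only part of what the source reports. "The series", "measured", "known", "first", "only" and "open" are said of these compounds alone.

Among the measured compounds shown here, compound 3 `CNC(=O)c1ccc(-c2nn(Cc3ccccc3)c3ccccc23)cc1` is one of three compounds measured in a functional assay on cells (Platelet, Homo sapiens) for inhibition (a higher number here means a weaker inhibitor, a lower number a stronger inhibitor), alongside compound 1 `CCOC(=O)c1ccc(-c2nn(Cc3ccccc3OC)c3ccccc23)cc1` and compound 2 `CCCCn1nc(-c2ccc(C(=O)OCC)cc2)c2ccccc21`. In this assay compound 3 gives only a limit, > 10000 nM. Compound 1 likewise gives a limit, > 10000 nM. Compound 2 also gives a limit, > 10000 nM. For the measured compounds named here, the single measured step, a step that the two limits leave unreadable from compound 1 to compound 2, is therefore unreadable, and the limit of > 10000 nM in this assay, at which 3 of the 3 values shown sit, is all the evidence available. Compound 4 `CCOC(=O)/C=C/c1ccc(-c2nn(Cc3ccccc3)c3ccccc23)cc1` differs from compound 3 by 2-(ethoxycarbonyl)ethenyl in place of methylcarbamoyl on an aromatic carbon. Going by the values given here, no measured step bears on this change. Because the limit of > 10000 nM in this assay, at which 3 of the 3 values shown sit, shows every compound at the limit, compound 4 is expected to remain there as well, with an estimated a number no higher from compound 3 to compound 4 (the limit leaves the size open) of no readable size. The estimate for compound 4 is 10000 nM, with a range of 3000 nM to 30000 nM.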

Compound 4, half-maximal inhibitory concentration: > 10000 nM
Compound 4 was reported as a limit; the forecaster's own chance of this, stated with the estimate: 80%; the middle value lies on the limit itself.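

No step can be read from compound 3 to compound 4, as both stand only as limits in this assay. The compounds shown leave open which change, if any, would give a readable inhibition value: the limit of > 10000 nM in this assay, at which 4 of the 4 values shown sit.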